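Methyl Ester in Place of the Acid: Expected Solubility

This account rests on a few compounds, and the source may have more. Where it says the series, first, only, none or still open, it means among the compounds named here.

Going by the values given here, compound 2 `N[C@@H](CSNC(=O)[C@@H](CCC(F)(F)F)N(Cc1ccc(-c2ncon2)cc1F)S(=O)(=O)c1ccc(Cl)cc1)C(=O)O` gives 510 ug/mL in a physicochemical assay for solubility, at pH 2 (a higher number here means a more soluble compound, a lower number a less soluble compound), the only plain number among the two values shown. Compound 1 `NCCSNC(=O)[C@@H](CCC(F)(F)F)N(Cc1ccc(-c2ncon2)cc1F)S(=O)(=O)c1ccc(Cl)cc1` gives > 10000 ug/mL in this assay, which is a limit of the assay rather than a number (the limit of > 10000 ug/mL in this assay, at which 1 of the 2 values shown sits). Among the compounds with values here, the one measured step, an at least 19-fold lower number from compound 1 to compound 2 (1.29 log units; beyond the scatter), concerned the same carboxy group. Compound 3 `COC(=O)[C@@H](N)CSNC(=O)[C@@H](CCC(F)(F)F)N(Cc1ccc(-c2ncon2)cc1F)S(=O)(=O)c1ccc(Cl)cc1` differs from compound 2 by methyl in place of hydrogen on an oxygen next to a carbonyl group. Within the data shown here, no measured step covers this exact change, so the expectation is loose: the step of a 2.9-fold higher number from compound 2 to compound 3 (0.47 log units; beyond the scatter) is expected to be a modest rise. Compound 3 is therefore estimated at 1500 ug/mL, with a range from 300 ug/mL to 8000 ug/mL.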

Compound 3, solubility: 3900 ug/mL
Compound 3: middle estimate off by 2.6-fold (0.41 log units), on the low side, and the stated range covers the measured number.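

Replacing carboxy with methoxycarbonyl wins back part of the drop in this assay that the carboxy group brought, with a 7.6-fold higher number from compound 2 to compound 3 (0.88 log units; beyond the scatter). Even so, methoxycarbonyl does not return this position to the level seen with hydrogen, with an at least 2.5-fold lower number from compound 1 to compound 3 (0.40 log units; beyond the scatter). Compound 1 stands at a limit of the assay rather than a number, so that second step gives only a bound: the limit of > 10000 ug/mL in this assay, at which 1 of the 3 values shown sits.

Still open, on these data alone, is where an ethyl ester or a primary amide in place of the carboxy group would fall in this assay.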